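A few compounds are considered here, and "the series" means these few. Any claim that something is new, unique, unknown or untested is made for them only; others in the source may bear on it.

- Compound 1 `COc1ccc(C(N)=O)cc1/C=C/c1ccc(Cl)cc1`: 7100 nM
- Compound 2 `COc1ccc(C(N)=O)cc1/C=C/c1ccc(Cl)cc1Cl`: > 50000 nM

In an ADME assay on HCT-116 cells (Homo sapiens) for antiproliferative activity (a lower number here means a stronger inhibitor, a higher number a weaker inhibitor), compound 2 stands at > 50000 nM, which is a limit of the assay and not a number. Compound 3 `COc1ccc(C(N)=O)cc1/C=C/c1ccc(Cl)cc1F` differs from compound 2 at a single place: fluoro in place of chloro on an aromatic carbon. For the measured compounds named here, the one measured step that bears on this change is an at least 7.0-fold higher number from compound 1 to compound 2 (0.84 log units; beyond the scatter), which came with chloro in place of hydrogen on an aromatic carbon. Compound 3 puts fluoro at that same carbon, so a step to a lower number is expected, probably without a full return to the value of compound 1. The expected step is an at least 3.1-fold lower number from compound 2 to compound 3 (0.49 log units; beyond the scatter). For compound 3 the estimated value is 16000 nM, with an expected range of 5000 nM to 50000 nM.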

Compound 3, half-maximal inhibitory concentration: > 10000 nM
Compound 3: a limit, no number (the forecaster's own chance of this, stated with the estimate: 20%); the middle value is on the limit's open side.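

In this assay compound 3 gives > 10000 nM, a limit of the assay and not a number. Fluoro at this carbon, like chloro, thus yields no measured number, and the change from hydrogen to fluoro is known only as a floor: an at least 1.4-fold higher number from compound 1 to compound 3 (0.14 log units; that floor lies within the scatter). Compound 2 and compound 3 both end in limits, so the step between them cannot be read: the limit of > 50000 nM in this assay, at which 1 of the 3 values shown sits.

Going by these compounds, whether fluoro truly weakens the compound relative to hydrogen stays open. On these data alone, how a methyl group or an amine at this carbon would behave also stays open.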